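Quinone in place of dimethoxyphenyl on a pyrazole sulfonamide scaffold

A few compounds are considered here, and "the series" means these few. Any claim that something is new, unique, unknown or untested is made for them only; others in the source may bear on it.

Measured compounds:
compound 1 `COc1ccc(OC)c(-c2cc(-c3ccccc3)nn2-c2ccc(S(N)(=O)=O)cc2)c1` gives 31100 nM;
compound 2 `COc1ccc(OC)c(-c2cc(-c3ccccc3)nn2-c2ccc(S(=O)(=O)NC(C)=O)cc2)c1` gives 42600 nM;
compound 3 `COc1ccc(OC)c(-c2cc(-c3ccc(Cl)cc3)nn2-c2ccc(S(=O)(=O)NC(C)=O)cc2)c1` gives 50000 nM.

All three values come from a functional assay on cells (Cancer cell lines, Homo sapiens) for cytotoxicity, read by sulforhodamine B assay, with a stated time of 48 h; on this read-out higher numbers stand for weaker inhibition of growth and lower numbers for stronger inhibition of growth. Compound 2 stands in the middle of the three, and both of its neighbours sit within the usual scatter: the step of a 1.4-fold higher number from compound 1 to compound 2 (0.14 log units; within the scatter) and the step of a 1.2-fold higher number from compound 2 to compound 3 (0.07 log units; within the scatter) are each too small to count as a change.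

Compound 4 `CC(=O)NS(=O)(=O)c1ccc(-n2nc(-c3ccccc3)cc2C2=CC(=O)C=CC2=O)cc1` differs from compound 2 by a group of 8 heavy atoms (6 carbon, 2 oxygen; one six-membered non-aromatic ring of carbon only) in place of a group of 10 heavy atoms (8 carbon, 2 oxygen; one six-membered aromatic ring of carbon only), on an aromatic carbon. Neither measured step touches this part of the molecule; one altered the sulfonamide nitrogen and the other an aromatic carbon of the phenyl group, and both stayed within scatter. The data therefore give no direct guide to this exchange, and the only available pattern is that changes elsewhere left the read-out in this assay essentially unchanged.

On that basis compound 4 is expected to give a number close to compound 2, with a step of a 1.4-fold lower number from compound 2 to compound 4 (0.15 log units; within the scatter), and the estimate for compound 4 is 30000 nM, with a range from 5000 nM to 100000 nM.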

Compound 4, concentration for total growth inhibition: 100000 nM
For compound 4 the middle estimate is 3.3-fold (0.52 log units) below the measured one; measured number inside the range.
By their numbers in this assay, from the lowest: compounds 1, 2, 3 and 4 (each within the scatter of the next, the first and the last beyond it).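

This is the first change shown at the aromatic carbon of the five-membered aromatic ring, next to the ring nitrogen. Unlike the changes on the sulfonamide nitrogen and the phenyl group, it moves the read-out in this assay beyond the scatter: the non-aromatic six-membered ring in place of 2,5-dimethoxyphenyl gives a 2.3-fold higher number from compound 2 to compound 4 (0.37 log units; beyond the scatter), a modest step towards weaker inhibition of growth. Nothing measured here accounts for this step.

A single pair cannot separate the loss of the aromatic ring from the loss of the methoxy groups, and a plain phenyl or a dihydroxyphenyl group at this place would be needed to tell them apart. As far as these compounds go, it also remains open whether the same exchange has a similar effect on the free sulfonamide of compound 1 or on the chloro-bearing compound 3.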